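Nitro in Place of Chloro: Expectation for Compound 4

The source may hold more compounds than are shown below. What is called first, only, known or untested is meant among the compounds shown, and "the series" means these compounds.

Working notes on a small set of four compounds sharing one core. Compound 1 `COC(=O)C1(c2ccc([N+](=O)[O-])cc2)CC1CN1CCN(c2ccccn2)CC1`, compound 2 `COC(=O)C1(c2ccc(Cl)cc2)CC1CN1CCN(c2ccccn2)CC1` and compound 3 `COC(=O)C1(c2ccc(Cl)cc2)CC1CN1CCN(c2ncccn2)CC1` have been measured in an assay for displacement of a labelled ligand from Sigma non-opioid intracellular receptor 1 (Cavia porcellus); on this read-out higher numbers stand for weaker inhibition and lower numbers for stronger inhibition. In this assay compound 1 gives 769 nM, compound 2 gives 707 nM and compound 3 gives 350 nM, the lowest number of the three, with both other numbers beyond the scatter from it.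

Two single changes connect the measured compounds. Compound 1 differs from compound 2 by nitro in place of chloro on an aromatic carbon, and that step read a 1.1-fold higher number from compound 2 to compound 1 (0.04 log units; within the scatter). Compound 3 differs from compound 2 by pyrimidin-2-yl in place of pyridin-2-yl on an amine nitrogen in a ring, and that step read a 2.0-fold lower number from compound 2 to compound 3 (0.31 log units; beyond the scatter).

Compound 4 `COC(=O)C1(c2ccc([N+](=O)[O-])cc2)CC1CN1CCN(c2ncccn2)CC1` has not yet been measured in this assay. It differs from compound 3 by nitro in place of chloro on an aromatic carbon, the same change that was made from compound 2 to compound 1, at a place described in the same words. The two cores on which the change is made differ only by pyrimidin-2-yl in place of pyridin-2-yl on an amine nitrogen in a ring.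

The change has been seen once so far, and the step it made lay within the scatter. Resting on that single earlier occurrence, a 1.1-fold higher number from compound 2 to compound 1 (0.04 log units; within the scatter), the expected step is a 1.1-fold higher number from compound 3 to compound 4 (0.04 log units; within the scatter). Compound 4 is therefore estimated at 380 nM, with the likely range between 190 nM and 760 nM. One earlier occurrence is a thin basis, so the range is kept wide.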

Compound 4, inhibition constant: 619 nM
The estimate for compound 4 lay 1.6-fold (0.21 log units) below the measured number; the measured number falls inside the stated range.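

In this assay, nitro in place of chloro gives a 1.8-fold higher number from compound 3 to compound 4 (0.25 log units; within the scatter), and this step does not differ from the one seen earlier on the other core: the same change on two cores in this assay, a 1.1-fold higher number (0.04 log units; within the scatter) from compound 2 to compound 1 and a 1.8-fold higher number (0.25 log units; within the scatter) from compound 3 to compound 4, 1.6-fold (0.21 log units) apart, within the scatter of two such steps. Pyrimidin-2-yl in place of pyridin-2-yl, now read on the nitro-bearing core, gives a 1.2-fold lower number from compound 1 to compound 4 (0.09 log units; within the scatter), and its two readings likewise do not differ: the same change on two cores in this assay, a 2.0-fold lower number (0.31 log units; beyond the scatter) from compound 2 to compound 3 and a 1.2-fold lower number (0.09 log units; within the scatter) from compound 1 to compound 4, 1.6-fold (0.21 log units) apart, within the scatter of two such steps. Across these four compounds, both changes therefore carry from one core to the other with no sign that the core alters them, but this rests on two occurrences of each change and does not show that the steps are identical, nor that they would hold on other cores; the pyrimidin-2-yl step lies beyond the scatter on the chloro-bearing core and within it on the nitro-bearing core, so whether that step is a real gain on both remains unsettled.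

The compounds shown leave open how other groups on the same aromatic carbon, such as an amine or a carboxylic acid, would read against chloro and nitro. They also leave open whether the two steps would persist if the methyl ester of the shared core gave way to an amide or a longer ester chain.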